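Changing the Urea Side Group from Compound 3 to Compound 4

The source may report more compounds than this note shows. Statements on the series, on what has been measured and on what is new or still open speak of the compounds shown alone.

Three compounds share one core and differ only in the group on the urea nitrogen. Compound 1 `Cc1ccccc1NC(=O)N1CCC(c2nc(-c3ccc4ccccc4n3)no2)CC1` gives 440 nM in a functional assay on Shh Light II cells (Mus musculus) for inhibition, read by a luciferase reporter (on this read-out lower numbers stand for stronger inhibition and higher numbers for weaker inhibition), compound 2 `N#Cc1ccccc1NC(=O)N1CCC(c2nc(-c3ccc4ccccc4n3)no2)CC1` gives 190 nM, and compound 3 `O=C(NCC1CCC1)N1CCC(c2nc(-c3ccc4ccccc4n3)no2)CC1` gives 410 nM. Compound 3 thus stands second highest of the three: close to compound 1, as a 1.1-fold lower number from compound 1 to compound 3 (0.03 log units; within the scatter) shows, and separated from compound 2 by a 2.2-fold higher number from compound 2 to compound 3 (0.33 log units; beyond the scatter). Compound 4 `O=C(NC1CCS(=O)(=O)CC1)N1CCC(c2nc(-c3ccc4ccccc4n3)no2)CC1` is not yet measured; it differs from compound 3 by 1,1-dioxothian-4-yl in place of cyclobutylmethyl on an amide-type nitrogen. Among the compounds with values here, no measured step brings in a six-membered non-aromatic ring with 1 hetero atom, so only the modest spread among the three measured groups guides the guess. The expected step of a 1.0-fold lower number from compound 3 to compound 4 (0.01 log units; within the scatter) is small, within the scatter. Compound 4 is therefore estimated at 400 nM, likely between 150 nM and 1100 nM.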

Compound 4, half-maximal inhibitory concentration: 360 nM
For compound 4 the middle estimate is 1.1-fold (0.05 log units) above the measured one, and the stated range covers the measured number.
By their numbers in this assay, from the lowest: compounds 2, 4, 3 and 1 (each within the scatter of the next, the first and the last beyond it).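

The amide-type nitrogen takes the 1,1-dioxothian-4-yl group, with its sulfur and oxygen atoms, without a step beyond the scatter in this assay: a 1.1-fold lower number from compound 3 to compound 4 (0.06 log units; within the scatter), a 1.2-fold lower number from compound 1 to compound 4 (0.09 log units; within the scatter) and a 1.9-fold higher number from compound 2 to compound 4 (0.28 log units; within the scatter). Unlike compound 1 and compound 3, compound 4 is not set apart from compound 2 by more than the scatter. Nothing measured here offers a reason for this result. Still open, from the compounds shown here alone, is how the same six-membered ring without its oxygen atoms would read, and whether a carboxylic acid, an amine or a longer chain on this nitrogen would stay in this range.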